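The source may report more compounds than this note shows. Statements on the series, on what has been measured and on what is new or still open speak of the compounds shown alone.

Series of sulfonamides on a shared core: compound 1 `Cc1ccc(S(=O)(=O)Nc2ccc3oc(-c4ccccc4)nc3c2)cc1`, compound 2 `O=S(=O)(Nc1ccc(-c2nc3ccccc3o2)cc1)c1ccccc1Cl` and compound 3 `Cc1ccccc1S(=O)(=O)Nc1ccc2oc(-c3ccccc3)nc2c1`. In an assay on isolated protein for inhibition of malate dehydrogenase, mitochondrial (Sus scrofa), with stated times of 45 min and 30 min (on this read-out lower numbers stand for stronger inhibition and higher numbers for weaker inhibition), compound 1 returns only a limit, > 63000 nM. Compound 2 likewise gives only a limit in this assay, > 63000 nM. Compound 3 also stands at a limit in this assay, > 63000 nM. Going by the values given here, the single step between measured neighbours, a step that the two limits leave unreadable from compound 1 to compound 3, cannot be read because both of its ends share (the limit of > 63000 nM in this assay, at which 3 of the 3 values shown sit). Compound 4 `COc1cccc(S(=O)(=O)Nc2ccc3oc(-c4ccccc4)nc3c2)c1` carries 3-methoxyphenyl in place of 2-methylphenyl on a sulfonyl sulfur. Among the compounds with values here, no measured step bears on this change, and every value shown is a limit, so no direction beyond the scatter can be drawn from the series. Compound 4 is therefore expected to remain at the limit, estimated at 63000 nM with a range from 25000 nM to 250000 nM. The expected step is a number no higher from compound 3 to compound 4 (the limit leaves the size open).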

Compound 4, half-maximal inhibitory concentration: > 63000 nM
Compound 4 was reported as a limit; the forecaster's own chance of this, stated with the estimate: 85%; the middle value sits exactly at the limit.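

No new step can be read from compound 3 to compound 4 or from compound 1 to compound 4, because both ends of each step share one limit: the limit of > 63000 nM in this assay, at which 4 of the 4 values shown sit. The compounds shown leave open whether any group on the sulfonyl sulfur gives a readable value rather than a limit.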